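Shortening the chain on the aromatic nitrogen

This account rests on a few compounds, and the source may have more. Where it says the series, first, only, none or still open, it means among the compounds named here.

Measured in a functional assay on A549 cells (Homo sapiens) for cytotoxicity, read by MTT assay, with a stated time of 48 h; on this read-out lower numbers stand for stronger inhibition and higher numbers for weaker inhibition:
- compound 1 `CC(C)n1c(/C=C2/C(=O)Nc3ccc(Br)cc32)nc2ccccc21`: 8630 nM
- compound 2 `Cn1c(/C=C2/C(=O)Nc3ccc([N+](=O)[O-])cc32)nc2ccccc21`: > 50000 nM, a limit
- compound 3 `CCn1c(/C=C2/C(=O)Nc3ccc(Br)cc32)nc2ccccc21`: > 50000 nM, a limit

Compound 3 gives no number, only a limit: > 50000 nM. This is the limit of > 50000 nM in this assay, at which 2 of the 3 values shown sit.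

Compound 4 `Cn1c(/C=C2/C(=O)Nc3ccc(Br)cc32)nc2ccccc21` differs from compound 3 by a single change: hydrogen in place of methyl on a saturated chain carbon bound to an aromatic nitrogen. In words, hydrogen replaces methyl on a saturated chain carbon bound to an aromatic nitrogen, so ethyl becomes methyl.

Given the one measured step of this kind, an at least 5.7-fold higher number from compound 1 to compound 3 (0.76 log units; beyond the scatter), a move toward a higher number in this assay, or none beyond the scatter, is expected. The expected step is a step that the limit leaves unreadable from compound 3 to compound 4. Compound 4 is estimated at 55000 nM, with an expected range from 20000 nM to 100000 nM.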

Compound 4, half-maximal inhibitory concentration: 41200 nM
Estimate against measurement, compound 4: 1.3-fold (0.13 log units) above, and the stated range covers the measured number.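

In this assay, compound 4 gives a real number for a methyl on the aromatic nitrogen, so methyl in place of isopropyl on an aromatic nitrogen can now be sized as a modest step: a 4.8-fold higher number from compound 1 to compound 4 (0.68 log units; beyond the scatter). The change from ethyl to methyl gives an at least 1.2-fold lower number from compound 3 to compound 4 (0.08 log units; that floor lies within the scatter), and the change from nitro to bromo gives an at least 1.2-fold lower number from compound 2 to compound 4 (0.08 log units; that floor lies within the scatter). Neither of these two changes can be read further, because compound 3 and compound 2 each give only a limit: the limit of > 50000 nM in this assay, at which 2 of the 4 values shown sit.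

Still open, on these data alone, is whether a longer chain, such as butyl, or a chain ending in an amine would give a lower number than isopropyl does.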